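Aryl swap at the pyridine and Vero cell cytotoxicity

The compounds below may be only part of what the source reports. "The series", "measured", "known", "first", "only" and "open" are said of these compounds alone.

Measured so far:
- compound 1 `COc1nc(-c2cnsc2)ccc1[C@@H](c1ccccc1)[C@@](O)(CCN(C)C)c1cccc2ccccc12`: in a toxicity assay on Vero cells (Chlorocebus sabaeus) for cytotoxicity (on this read-out higher numbers stand for lower toxicity in this test and lower numbers for higher toxicity in this test), compound 1 gives 26.3 ug/mL.
- compound 2 `COc1nc(-c2ccccc2F)ccc1[C@@H](c1ccccc1)[C@@](O)(CCN(C)C)c1cccc2ccccc12`: in this assay compound 2 gives only a limit, > 50 ug/mL.

Among the measured compounds shown here, compound 1 holds the only number given; the other value is a limit (the limit of > 50 ug/mL in this assay, at which 1 of the 2 values shown sits). For the measured compounds named here, the one measured step, an at least 1.9-fold higher number from compound 1 to compound 2 (0.27 log units; that floor lies within the scatter), swaps the aryl group at the same place as the change now considered. Compound 3 `COc1nc(-c2ccc(OC(F)(F)F)cc2)ccc1[C@@H](c1ccccc1)[C@@](O)(CCN(C)C)c1cccc2ccccc12` differs from compound 1 by 4-(trifluoromethoxy)phenyl in place of 1,2-thiazol-4-yl on an aromatic carbon. By analogy with that step, compound 3 is expected to give a number no lower than compound 1, the step of a 1.5-fold higher number from compound 1 to compound 3 (0.18 log units; within the scatter) being the expectation, with a fair chance of a limit. The estimate for compound 3 in this assay is 40 ug/mL, ranging from 20 ug/mL to 80 ug/mL.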

Compound 3, half-maximal cytotoxic concentration: > 50 ug/mL
Compound 3 ended at the assay's limit; the forecaster's own chance of this, stated with the estimate: 40%; middle value at least 1.2-fold (0.09 log units) away from the limit.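

The change from 1,2-thiazol-4-yl to 4-(trifluoromethoxy)phenyl reads as an at least 1.9-fold higher number from compound 1 to compound 3 (0.27 log units; that floor lies within the scatter), so a second carbon-only aromatic ring at this place also ends at the limit rather than at a number. The step between compound 2 and compound 3 cannot be read, as both values are limits. The values now gather at one limit: the limit of > 50 ug/mL in this assay, at which 2 of the 3 values shown sit.

As far as these compounds go, how far compound 2 and compound 3 lie past that limit stays open. Also open, from the compounds shown here alone, is whether a phenyl carrying an amine or a carboxylic acid at this place would give a number under the limit.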